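Boron-bearing amides: aryl substitution on the anilide ring

This account rests on a few compounds, and the source may have more. Where it says the series, first, only, none or still open, it means among the compounds named here.

Measured so far:
- compound 1, `O=C(CCc1cccc2c1B(O)OC2)Nc1ccccc1`: 200 nM in a functional assay on SK-OV-3 cells (Homo sapiens) for antiproliferative activity, read by MTT assay, with a stated time of 72 h; a higher number here means a weaker inhibitor, a lower number a stronger inhibitor
- compound 2, `CCOC(=O)c1ccc(NC(=O)CCc2cccc3c2B(O)OC3)cc1`: only a limit is recorded for compound 2, > 100000 nM

Among the measured compounds shown here, compound 1 is the single compound with a number in this assay; the other recorded result is a limit, and compound 1 therefore serves as the reference point. For the measured compounds named here, the one measured step, an at least 500-fold higher number from compound 1 to compound 2 (2.69 log units; beyond the scatter), comes from ethoxycarbonyl in place of hydrogen on an aromatic carbon, and it sits at the limit of > 100000 nM in this assay, at which 1 of the 2 values shown sits.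

Compound 3, `O=C(CCc1cccc2c1B(O)OC2)Nc1cccc(-c2ccc(Cl)cc2)c1`, carries 4-chlorophenyl in place of hydrogen on an aromatic carbon. The change again adds a group to the same anilide ring, though a different group at a different carbon, so the measured step is only a loose guide. A weakening is expected, estimated as a 10-fold higher number from compound 1 to compound 3 (1.00 log units; beyond the scatter), with wide uncertainty. Compound 3 is thus expected to give about 2000 nM in this assay, within 200 nM to 50000 nM.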

Compound 3, half-maximal inhibitory concentration: 220 nM
Compound 3: middle estimate off by 9.1-fold (0.96 log units), on the high side; the range from low to high includes it.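

In this assay, 4-chlorophenyl on an aromatic carbon, meta to a large group, costs nothing that can be read (a 1.1-fold higher number from compound 1 to compound 3 (0.04 log units; within the scatter)). Substitution on the anilide ring is therefore not in itself enough to lose activity, and this carbon carries 7 further heavy atoms, including a whole six-membered aromatic ring, with the result still within the scatter of compound 1. The loss recorded for compound 2 with ethoxycarbonyl thus cannot be read as applying to every substituent on this ring, and compound 2 remains a limit: the limit of > 100000 nM in this assay, at which 1 of the 3 values shown sits.

As far as these compounds go, it remains open whether the loss follows the ethoxycarbonyl group itself or the carbon that carries it. Also open, from the compounds shown here alone, is how a carboxylic acid, an amine or unsubstituted phenyl would behave at the carbon that carries 4-chlorophenyl in compound 3.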